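This account rests on a few compounds, and the source may have more. Where it says the series, first, only, none or still open, it means among the compounds named here.

Series on a shared core, tested in a functional assay on HeLa cells (Homo sapiens) for inhibition, read by sulforhodamine B assay; on this read-out lower numbers stand for stronger inhibition and higher numbers for weaker inhibition. Compound 1 `O=C1C(N2CCCCC2)=CC(=O)c2c1nc1n2[C@H]2OC[C@@H](O)[C@H]2OC1` gives > 16000 nM, which is a limit of the assay. Compound 3 `O=C1C(N2CCC2)=CC(=O)c2c1nc1n2[C@H]2OC[C@@H](O)[C@H]2OC1` gives > 16000 nM, also a limit. The step that the two limits leave unreadable from compound 1 to compound 3 is therefore not readable. Compound 2 `O=C1C=C(Nc2ccc(C(F)(F)F)cc2)C(=O)c2c1nc1n2[C@H]2OC[C@@H](O)[C@H]2OC1` gives > 8000 nM, a limit as well. It stands at the limit of > 8000 nM in this assay, at which 1 of the 3 values shown sits, while the other two values sit at the limit of > 16000 nM in this assay, at which 2 of the 3 values shown sit. Compound 4 `COc1ccccc1NC1=CC(=O)c2nc3n(c2C1=O)[C@H]1OC[C@@H](O)[C@H]1OC3` is not yet measured; it differs from compound 2 by 2-methoxyphenyl in place of 4-(trifluoromethyl)phenyl on an amine nitrogen. Among the measured compounds shown here, no measured step bears on this change, and no measured value in the set is a number, so no direction can be read. Compound 4 is expected to sit near the limits as well, with a step that the limit leaves unreadable from compound 2 to compound 4 around zero. The estimate for compound 4 is 10000 nM, with a range from 3000 nM to 40000 nM.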

Compound 4, half-maximal inhibitory concentration: 2950 nM
Estimate against measurement, compound 4: 3.4-fold (0.53 log units) above; the measured number lies below the stated range.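

Among the compounds shown, compound 4 alone gives a number rather than a limit in this assay, so the shared core can reach a readable value with 2-methoxyphenyl on the amine nitrogen. The change from 4-(trifluoromethyl)phenyl to 2-methoxyphenyl at this position gives an at least 2.7-fold lower number from compound 2 to compound 4 (0.43 log units; beyond the scatter). Compound 2 stands at a limit, so this step has a floor and no exact size: the limit of > 8000 nM in this assay, at which 1 of the 4 values shown sits.

Nothing shown separates the contribution of the methoxy group from the loss of the trifluoromethyl group. As far as these compounds go, it also remains open whether an unsubstituted phenyl or a 2-hydroxyphenyl on the same amine nitrogen would keep the value of compound 4.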